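Removing a Methyl from an Ester: Expected Potency Shift

The source may hold more compounds than are shown below. What is called first, only, known or untested is meant among the compounds shown, and "the series" means these compounds.

Measured compounds:
compound 1, `COc1cc(OC)c(/C=C/S(=O)(=O)Cc2ccc(OC)c([N+](=O)[O-])c2)c(OC)c1`: 2500 nM
compound 2, `COc1ccc(CS(=O)(=O)/C=C/c2c(OC)cc(O)cc2OC)cc1[N+](=O)[O-]`: 5000 nM
compound 3, `COC(=O)CNc1cc(CS(=O)(=O)/C=C/c2cc(OC)c(OC)c(OC)c2)ccc1OC`: 30000 nM

All three were tested in a functional assay on K562 cells (Homo sapiens) for cytotoxicity, read by trypan blue exclusion, with a stated time of 96 h; a higher number here means a weaker inhibitor, a lower number a stronger inhibitor. Compound 4, `COc1ccc(CS(=O)(=O)/C=C/c2cc(OC)c(OC)c(OC)c2)cc1NCC(=O)O`, has not been measured yet. It differs from compound 3 by hydrogen in place of methyl on an oxygen next to a carbonyl group. A related change has already been seen between compound 1 and compound 2, where the difference is hydrogen in place of methyl on an oxygen on an aromatic ring and the step was a 2.0-fold higher number from compound 1 to compound 2 (0.30 log units; within the scatter). The two changes are the same kind of change, not the same: in compound 1 the place is on an oxygen on an aromatic ring whose other neighbours are aromatic carbon, whereas in compound 3 it is on an oxygen next to a carbonyl group whose other neighbours are carbonyl carbon. The difference between the two cores of compound 1 and compound 3 is not broken down here.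

Because the earlier step of a 2.0-fold higher number from compound 1 to compound 2 (0.30 log units; within the scatter) stayed within the scatter, a similarly small step is expected from compound 3 to compound 4, namely a 1.5-fold higher number from compound 3 to compound 4 (0.18 log units; within the scatter), though the different place leaves wider room. Compound 4 is therefore estimated at 45000 nM, between 12000 nM and 170000 nM.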

Compound 4, half-maximal inhibitory concentration: 3000 nM
Compound 4: middle estimate off by 15-fold (1.18 log units), on the high side; measured number outside the range, below it.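

In this assay, putting hydrogen in place of methyl on an oxygen next to a carbonyl group, which turns the methoxycarbonyl group into a carboxy group, gave a 10-fold lower number from compound 3 to compound 4 (1.00 log units; beyond the scatter). Loss of a methyl from an oxygen therefore did not behave alike in the two places, and the small step seen on the first core was a poor guide to the second: the same change on two cores in this assay, a 2.0-fold higher number (0.30 log units; within the scatter) from compound 1 to compound 2 and a 10-fold lower number (1.00 log units; beyond the scatter) from compound 3 to compound 4, 20-fold (1.30 log units) apart, beyond the scatter of two such steps. This does not show whether the core or the place of the change sets the gap, since the two steps differ in both and each rests on a single pair of compounds.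

The compounds shown leave open whether an ethyl ester or an amide at this place would read like compound 3 or like compound 4. Also open, as far as these compounds go, is whether the same methoxycarbonyl to carboxy change would bring a similar step on a different core.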